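The source may hold more compounds than are shown below. What is called first, only, known or untested is meant among the compounds shown, and "the series" means these compounds.

Measured compounds:
compound 1 `C#CCOc1cc(O)c2c(c1)O[C@H](c1ccc(OC)c(O)c1)C/C2=N\O` — 19100 nM in a functional assay on RAW264.7 cells (Mus musculus) for inhibition, read by Griess assay, with stated times of 2 h and 24 h; on this read-out lower numbers stand for stronger inhibition and higher numbers for weaker inhibition
compound 2 `CCCn1cc(COc2cc(O)c3c(c2)O[C@H](c2ccc(OC)c(O)c2)CC3=O)nn1` — 9670 nM in this assay
compound 3 `COc1ccc([C@@H]2C/C(=N\O)c3c(O)cc(OCc4cn(Cc5ccccc5C)nn4)cc3O2)cc1O` — 18000 nM in this assay

Of the compounds shown here, three sharing one core have been measured in this assay. Compound 1 gives 19100 nM, compound 2 gives 9670 nM and compound 3 gives 18000 nM. The gaps from compound 2 to compound 3 and from compound 2 to compound 1 both fall within the usual scatter of such measurements, so compound 2 cannot be set apart from either of its neighbours on these numbers; the three sit together at a level where no ordering can be read.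

The next compound, compound 4 `CCCCn1cc(COc2cc(O)c3c(c2)O[C@H](c2ccc(OC)c(O)c2)CC3=O)nn1`, is made from compound 2 by a single change: methyl in place of hydrogen on a saturated chain carbon, three bonds along the chain from an aromatic nitrogen. No pair of measured compounds differing only in one place is available, so nothing shown gives the size of such a step directly. With the change confined to the outer end of a saturated chain, the account expects no step beyond the scatter in this assay, with the direction left open. Compound 4 is therefore estimated at 9500 nM, with a range from 4000 nM to 22000 nM, which corresponds to an expected step of a 1.0-fold lower number from compound 2 to compound 4 (0.01 log units; within the scatter).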

Compound 4, half-maximal inhibitory concentration: 13900 nM
Compound 4: the middle estimate sits 1.5-fold (0.17 log units) below what was measured, and the stated range covers the measured number.
By their numbers in this assay, from the lowest: compounds 2, 4, 3 and 1 (each within the scatter of the next).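

Among the compounds shown here, this pair gives the first direct reading of a change in one place. In this assay, for the compounds shown here, methyl in place of hydrogen on a saturated chain carbon, three bonds along the chain from an aromatic nitrogen, gives a 1.4-fold higher number from compound 2 to compound 4 (0.16 log units; within the scatter), so going from propyl to butyl at this outer end of the chain produces no step that can be told from the scatter. Nothing shown links this small step to any measured property.

Going by these compounds, one step of a single carbon says little about the chain as a whole, so it remains open whether a longer chain such as hexyl, or a chain ending in an amine or a carboxylic acid, would give a step beyond the scatter. It is also open whether the same change would give a similar step on the core of compound 3, since no pair shown tests it there.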